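Working notes: compounds 1 to 4 in one cell assay

This account rests on a few compounds, and the source may have more. Where it says the series, first, only, none or still open, it means among the compounds named here.

Measured so far:
compound 1 `CCOC(=O)CNc1nc(Nc2cccc(OC)c2)ncc1[N+](=O)[O-]` — 36100 nM
compound 2 `CCOC(=O)CNc1ncc([N+](=O)[O-])c(N(CC(=O)OCC)Cc2ccccc2)n1` — > 100000 nM, a limit of the assay
compound 3 `CCOC(=O)CN(Cc1ccccc1)c1nc(Nc2ccccc2)ncc1[N+](=O)[O-]` — > 100000 nM, a limit of the assay

Within the data shown here, compound 1 is the only member with a number in a functional assay on A549 cells (Homo sapiens) for antiproliferative activity, read by MTT assay, with a stated time of 48 h; a lower number here means a stronger inhibitor, a higher number a weaker inhibitor; compound 1 gives 36100 nM there. Compound 2 reaches only the limit > 100000 nM in this assay. Compound 3 likewise stops at the limit > 100000 nM in this assay. The step that the two limits leave unreadable from compound 2 to compound 3 cannot be read since both of its ends sit at the limit of > 100000 nM in this assay, at which 2 of the 3 values shown sit.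

Compound 4 `CCOC(=O)CNc1nc(NCc2ccccc2)ncc1[N+](=O)[O-]` differs from compound 1 by benzyl in place of 3-methoxyphenyl on a nitrogen on an aromatic ring. No measured step touches this position in a readable way: the only step shown, from compound 2 to compound 3, is unreadable and concerns a different substituent pattern. The expectation therefore rests on compound 1 alone, with wide uncertainty. Compound 4 is expected near 60000 nM, within 15000 nM to 250000 nM. The expected step of a 1.7-fold higher number from compound 1 to compound 4 (0.22 log units; within the scatter) is a modest weakening, with a fair chance that this assay returns only a limit.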

Compound 4, half-maximal inhibitory concentration: 74400 nM
For compound 4 the middle estimate is 1.2-fold (0.09 log units) below the measured one, and the stated range covers the measured number.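

The exchange of 3-methoxyphenyl for benzyl on a nitrogen on an aromatic ring gives, in this assay, a 2.1-fold higher number from compound 1 to compound 4 (0.31 log units; beyond the scatter). Among these compounds, this is the first readable step, and it shows that this position responds to the change only modestly, with compound 4 still giving a number rather than a limit. The step between compound 2 and compound 3 cannot be read, so any comparison rests on this one pair: the limit of > 100000 nM in this assay, at which 2 of the 4 values shown sit.

With only two groups compared at this position, the compounds shown do not separate the loss of the methoxy group from the change from a phenyl to a benzyl group. As far as these compounds go, the effect of a simple unsubstituted phenyl, a longer chain or an amine at this position stays open, as does that of a carboxylic acid in place of the ethyl ester.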